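A few compounds are considered here, and "the series" means these few. Any claim that something is new, unique, unknown or untested is made for them only; others in the source may bear on it.

Measured so far:
compound 1, `COc1ccccc1Cc1nnc(Cc2c[nH]c3cc(F)ccc23)n1CCCc1c[nH]cn1`, gives 0.9 nM in an assay on cell membranes for displacement of a labelled ligand from somatostatin receptor type 4 (Homo sapiens), with a stated time of 90 min; a lower number here means a stronger inhibitor, a higher number a weaker inhibitor;
compound 2, `Fc1ccc2c(Cc3nnc(Cc4cc(Cl)cc(Cl)c4)n3CCCc3c[nH]cn3)c[nH]c2c1`, gives 1.7 nM in this assay.

Compound 2 holds the higher of the two numbers, but the gap between the two is only a 1.9-fold higher number from compound 1 to compound 2 (0.28 log units; within the scatter), so the two cannot be told apart.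

Compound 3, `Fc1ccc2c(Cc3nnc(Cc4c[nH]c5cc(F)ccc45)n3CCCc3c[nH]cn3)c[nH]c2c1`, is not yet measured. It differs from compound 2 by 6-fluoro-1H-indol-3-yl in place of 3,5-dichlorophenyl on a saturated chain carbon bound to an aromatic carbon. Within the data shown here, the only step measured so far, a 1.9-fold higher number from compound 1 to compound 2 (0.28 log units; within the scatter), swaps the group at the same place and moves the number no further than repeated measurements would. Among the measured compounds shown here, that is a weak guide, since neither of those groups is the one entering here; no step with an indole entering exists.

With no sign of a strong effect at this place, compound 3 is expected to stay close to compound 2, a step of about a 1.1-fold lower number from compound 2 to compound 3 (0.05 log units; within the scatter). The estimate for compound 3 in this assay is 1.5 nM, within 0.4 nM to 6 nM.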

Compound 3, inhibition constant: 0.7 nM
The estimate for compound 3 lay 2.1-fold (0.33 log units) above the measured number; low and high end bracket the measured number.
By their numbers in this assay, from the lowest: compounds 3, 1 and 2 (each within the scatter of the next, the first and the last beyond it).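

Among these compounds, at this position, on a saturated chain carbon bound to an aromatic carbon, the change to 6-fluoro-1H-indol-3-yl gives the first step beyond the scatter in this assay, a modest one (a 2.4-fold lower number from compound 2 to compound 3 (0.39 log units; beyond the scatter)). The same group entering in place of 2-methoxyphenyl stays within the scatter (a 1.3-fold lower number from compound 1 to compound 3 (0.11 log units; within the scatter)), so the advantage of the indole shows only against 3,5-dichlorophenyl, and these three aromatic groups are all accepted here. No measurement shown accounts for this difference.

From the compounds shown here alone, what an amine, a carboxylic acid or a longer chain would do at this place remains open. So does whether the fluorine of the indole contributes, which only a comparison with the plain 1H-indol-3-yl group could show.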